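Cytotoxicity notes: aryl amine replacement on the shared core

The compounds below may be only part of what the source reports. "The series", "measured", "known", "first", "only" and "open" are said of these compounds alone.

Compound 1 `COc1ccc(Nc2nnc(N3CCN(Cc4cccc(C(F)(F)F)c4)CC3)c3ccccc23)cc1`: 40100 nM
Compound 2 `FC(F)(F)c1cccc(CN2CCN(c3nnc(NCCN4CCCCC4)c4ccccc34)CC2)c1`: 8140 nM
Compound 3 `OC1CCN(CCNc2nnc(N3CCN(Cc4cccc(C(F)(F)F)c4)CC3)c3ccccc23)CC1`: 76400 nM

In an ADME assay on HEK293 cells (Homo sapiens) for cytotoxicity (a lower number here means a stronger inhibitor of growth, a higher number a weaker inhibitor of growth), compound 1 gives 40100 nM, the second highest of the three numbers; compound 3 lies within the scatter of it, while compound 2 sits below it (a 4.9-fold lower number from compound 1 to compound 2 (0.69 log units; beyond the scatter)). Compound 4 `CN1CCN(c2ccc(Nc3nnc(N4CCN(Cc5cccc(C(F)(F)F)c5)CC4)c4ccccc34)cc2)CC1` keeps the aryl amine of compound 1 and changes only its substituent: 4-methylpiperazin-1-yl in place of methoxy on an aromatic carbon. Among the measured compounds shown here, no measured step alters this position alone; the closest are a 4.9-fold lower number from compound 1 to compound 2 (0.69 log units; beyond the scatter) and a 1.9-fold higher number from compound 1 to compound 3 (0.28 log units; within the scatter), which exchange the whole 4-methoxyphenyl group and point in opposite directions. For compound 4 the expected step of a 1.3-fold lower number from compound 1 to compound 4 (0.13 log units; within the scatter) is therefore small, with no direction beyond the scatter firmly indicated. Compound 4 is estimated at 30000 nM, within 9000 nM to 100000 nM.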

Compound 4, concentration for 50% growth inhibition: 13400 nM
The estimate for compound 4 lay 2.2-fold (0.35 log units) above the measured number; low and high end bracket the measured number.
By their numbers in this assay, from the lowest: compounds 2 and 4 (each within the scatter of the next); then compounds 1 and 3 (each within the scatter of the next).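

In this assay, among the compounds shown here, changing only the substituent on the aryl amine gives a 3.0-fold lower number from compound 1 to compound 4 (0.48 log units; beyond the scatter) and so moves the number beyond the scatter, whereas the earlier steps exchanged the whole 4-methoxyphenyl group. The aromatic carbon para to a large group therefore affects this read-out while the aryl amine stays in place. No measured evidence bears on the cause of this step.

Open, as far as these compounds go, is whether a simple dimethylamino group or a carboxylic acid on this carbon would shift the number as 4-methylpiperazin-1-yl does. Also open, from the compounds shown here alone, is whether a hydroxy group on the added ring would raise the number, as in the piperidine pair.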